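Thiophene for tolyl on the N-hydroxyindole dinitrile core

A few compounds are considered here, and "the series" means these few. Any claim that something is new, unique, unknown or untested is made for them only; others in the source may bear on it.

Compound 1 `N#Cc1cc2cc(-c3ccccc3)n(O)c2cc1C#N`: 10300 nM
Compound 2 `Cc1ccc(-c2cc3cc(C#N)c(C#N)cc3n2O)cc1`: 821 nM
Compound 3 `COc1ccc(-c2cc3cc(C#N)c(C#N)cc3n2O)cc1`: 1790 nM

Of the compounds shown here, three sharing one core have been measured in an assay on isolated protein for inhibition of Amine oxidase [flavin-containing] B (Homo sapiens), read by fluorescence and spectrophotometry, with a stated time of 20 min; a lower number here means a stronger inhibitor, a higher number a weaker inhibitor. Compound 1 `N#Cc1cc2cc(-c3ccccc3)n(O)c2cc1C#N` carries an unsubstituted phenyl and gives 10300 nM. Adding a methyl on an aromatic carbon, a 13-fold lower number from compound 1 to compound 2 (1.10 log units; beyond the scatter), and adding a methoxy there instead, a 5.8-fold lower number from compound 1 to compound 3 (0.76 log units; beyond the scatter). Between the two substituted compounds there is a 2.2-fold higher number from compound 2 to compound 3 (0.34 log units; beyond the scatter). Compound 2 therefore stands lowest of the three numbers in this assay, with compound 3 nearest and compound 1 furthest away.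

Compound 4 `N#Cc1cc2cc(-c3cccs3)n(O)c2cc1C#N` differs from compound 2 by thiophen-2-yl in place of 4-methylphenyl on an aromatic carbon. For the measured compounds named here, no measured step swaps the aryl ring itself; the steps that bear on it show only that a substituent on the phenyl lowers the number relative to the bare ring of compound 1. Compound 4 carries no such substituent, so the thiophen-2-yl is expected to land between the bare phenyl of compound 1 and the tolyl of compound 2, giving a step upward in this assay. The expected step is a 3.7-fold higher number from compound 2 to compound 4 (0.56 log units; beyond the scatter), and compound 4 is estimated at 3000 nM with a range of 800 nM to 12000 nM.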

Compound 4, half-maximal inhibitory concentration: > 100000 nM
Compound 4: a limit, no number; the forecaster's own chance of this, stated with the estimate: 5%; at least 33-fold (1.52 log units) between middle value and limit.
By their numbers in this assay, from the lowest: compound 2; then compound 3; then compound 1. At a limit, above all of these: compound 4.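

Compound 4 gives only a limit in this assay, not a number: the limit of > 100000 nM in this assay, at which 1 of the 4 values shown sits.

The earlier compounds shown here varied only a substituent on the phenyl, and both substituents lowered the number, whereas exchanging the ring itself at this place, on the aromatic carbon next to the ring nitrogen, gives an at least 120-fold higher number from compound 2 to compound 4 (2.08 log units; beyond the scatter). Measured against the bare phenyl, with no substituent involved in the change, the same exchange gives an at least 9.7-fold higher number from compound 1 to compound 4 (0.98 log units; beyond the scatter), so the ring itself matters here and not only what is attached to it, and thiophen-2-yl does not stand in for phenyl in this assay.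

The compounds shown leave open whether this loss belongs to thiophen-2-yl alone or extends to other five-membered aromatic rings, such as furan-2-yl or a pyrrole ring. They also leave open whether a methyl or methoxy on the thiophene would lower the number as each does on the phenyl, and how an amine or a carboxylic acid on the phenyl would compare with the methyl of compound 2.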